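The compounds below may be only part of what the source reports. "The series", "measured", "known", "first", "only" and "open" are said of these compounds alone.

Measured so far in a functional assay on HOP-92 cells (Homo sapiens) for inhibition, read by sulforhodamine B assay, with a stated time of 48 h, tested at 10 uM; a lower number here means a stronger effect, a higher number a weaker effect of the compound at the concentration tested:

compound 1, `COc1cc2cc(Oc3ccc(NC(=O)Nc4ccc(C(F)(F)F)cc4)cc3)c(C)nc2cc1OC`: 56.3%
compound 2, `COc1cc2cc(Oc3ccc(NC(=O)Nc4cccc(C(F)(F)F)c4)cc3)c(C)nc2cc1OC`: -29.5%

Compound 2 stands lowest of the two numbers in this assay. Its nearest neighbour is compound 1, and the one step shown, a number 85.8 percentage points lower from compound 1 to compound 2 (beyond the scatter), separates them; that step is the move of the trifluoromethyl group from one position to another on the phenyl carried by the amide-type nitrogen.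

Compound 3, `COc1cc2cc(Oc3ccc(NC(=O)Nc4ccc(Cl)c(C(F)(F)F)c4)cc3)c(C)nc2cc1OC`, is not yet measured. It differs from compound 2 in one place: chloro in place of hydrogen on an aromatic carbon. For the measured compounds named here, the single measured step concerns a shift of the trifluoromethyl group and not the entry of a chloro, so it does not bear on this change in any direct way. Nothing measured tells how a chloro entering this ring alters the read-out, and a wide range is the honest answer. The expected step is a number 14.5 percentage points higher from compound 2 to compound 3 (beyond the scatter), which is not expected to go beyond the scatter. Compound 3 is estimated at -15%, with a range from -55% to 30%.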

Compound 3, a percentage reported as activity, at one concentration (the size of the read-out at that concentration, not a potency): -22.3%
Compound 3: middle estimate off by 7.3 percentage points, on the high side, within the range that was stated.
By their numbers in this assay, from the lowest: compounds 2 and 3 (each within the scatter of the next); then compound 1.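

In this assay the aromatic carbon ortho to a trifluoromethyl group and para to a large group accepts chloro with a number 7.2 percentage points higher from compound 2 to compound 3 (within the scatter), so this position, unlike the shift of the trifluoromethyl group, does not separate the two compounds. The other comparison, a number 78.6 percentage points lower from compound 1 to compound 3 (beyond the scatter), shows that the large gap to compound 1 persists when 4-chloro-3-(trifluoromethyl)phenyl replaces 4-(trifluoromethyl)phenyl, so among these three compounds the read-out stays negative wherever a trifluoromethyl group occupies the 3 position named in these groups. No supporting measurement is available to explain why the chloro leaves the read-out within the scatter, or why the gap to compound 1 remains.

Going by these compounds, whether this position would accept a larger or different group, such as methoxy, an amine or a carboxylic acid, remains open, as does whether fluoro would behave like chloro. The compounds shown also leave open whether a chloro at this position would give the same read-out without the neighbouring trifluoromethyl group.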